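Adding a Second Chloro to the Amide Aryl Group

A few compounds are considered here, and "the series" means these few. Any claim that something is new, unique, unknown or untested is made for them only; others in the source may bear on it.

Measured so far:
Compound 1, `O=C(Nc1c(C(O)(C(F)(F)F)C(F)(F)F)ccc2ccccc12)C1CC1`: 751 nM
Compound 2, `O=C(Nc1c(C(O)(C(F)(F)F)C(F)(F)F)ccc2ccccc12)c1cccc(Cl)c1`: 98 nM

The measurements come from an assay on LtK cells with ATP-sensitive inward rectifier potassium channel 11 (Homo sapiens) as the target; on this read-out lower numbers stand for an effect already at smaller amounts and higher numbers for an effect only at larger amounts of compound. Compound 1 gives 751 nM in this assay and compound 2 gives 98 nM. Of the two numbers, compound 2 stands at the lower one, set apart from compound 1 by a step that lies beyond the scatter: a 7.7-fold lower number from compound 1 to compound 2 (0.88 log units; beyond the scatter).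

The next compound, compound 3 with structure `O=C(Nc1c(C(O)(C(F)(F)F)C(F)(F)F)ccc2ccccc12)c1cccc(Cl)c1Cl`, keeps the shared core and the amide of compound 2 and differs from it in a single place: chloro in place of hydrogen on an aromatic carbon.

Going by the values given here, no measured step of this study concerns a second chloro on the aryl ring; the single step recorded, from cyclopropyl to 3-chlorophenyl, speaks to the aryl group as a whole and not to further substitution on it. What is expected here therefore rests on the observation that compound 2 already reaches 98 nM and that one more small substituent is likely to shift the number only modestly, in either direction. The step from compound 2 to compound 3 is expected to be a 1.1-fold lower number from compound 2 to compound 3 (0.04 log units; within the scatter), within or near the scatter. For compound 3 the estimate in this assay is 90 nM, with a range from 30 nM to 270 nM.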

Compound 3, half-maximal effective concentration: > 10000 nM
Compound 3 ended at the assay's limit; the forecaster's own chance of this, stated with the estimate: 2%; middle value at least 110-fold (2.04 log units) from the limit.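

In this assay compound 3 gives > 10000 nM, which is a limit of the assay and not a number: the limit of > 10000 nM in this assay, at which 1 of the 3 values shown sits. Going by these compounds alone, the earlier compounds showed only that an aryl group on the amide could lower the number, whereas this result shows that an aromatic carbon ortho to a chloro group and ortho to a large group is highly sensitive to substitution, with a single chloro in place of hydrogen giving an at least 100-fold higher number from compound 2 to compound 3 (2.00 log units; beyond the scatter). The gain seen with 3-chlorophenyl therefore does not carry over to every chlorinated aryl group, and 2,3-dichlorophenyl in place of cyclopropyl gives an at least 13-fold higher number from compound 1 to compound 3 (1.12 log units; beyond the scatter).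

As far as these compounds go, it remains open whether a fluoro or a methyl group on the same aromatic carbon would keep the number close to that of compound 2, or whether any group there would end at the same limit. Also open is whether the loss depends on the two chloro groups being present together, and the compounds shown do not reveal what underlies it.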